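The source may hold more compounds than are shown below. What is called first, only, known or untested is meant among the compounds shown, and "the series" means these compounds.

Compound 3 `CCCCc1cc(C(=O)N[C@H](C)CCCc2cccnc2)ccc1-c1ccc(OC)c(OC)c1` in an assay (Canis lupus familiaris) for binding affinity to platelet-activating factor receptor (Homo sapiens), read by radioligand binding (on this read-out higher numbers stand for weaker inhibition and lower numbers for stronger inhibition), gives 4 nM, level with compound 2 `CCc1cc(C(=O)N[C@H](C)CCCc2cccnc2)ccc1-c1ccc(OC)c(OC)c1`, which gives 4 nM, and together these two are the lowest of the three numbers; compound 1 `COc1ccc(-c2ccc(C(=O)N[C@H](C)CCCc3cccnc3)cc2Br)cc1OC` gives 180 nM. Compound 4 `COc1ccc(-c2ccc(C(=O)N[C@H](C)CCCc3cccnc3)cc2[N+](=O)[O-])cc1OC` is not yet measured and differs from compound 3 by nitro in place of butyl on an aromatic carbon. For the measured compounds named here, no measured step places a nitro group on that aromatic carbon. Putting butyl in place of bromo there gave a 45-fold lower number from compound 1 to compound 3 (1.65 log units; beyond the scatter), while ethyl in place of hydrogen along the chain gave no change at the digits printed from compound 2 to compound 3 (within the scatter), so the alkyl itself seems to carry the gain. Taking the butyl away for a group that is not an alkyl is expected to raise the number again, with an expected step of a 38-fold higher number from compound 3 to compound 4 (1.57 log units; beyond the scatter). Compound 4 is therefore estimated at 150 nM, within a range of 40 nM to 600 nM.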

Compound 4, half-maximal inhibitory concentration: 200 nM
The estimate for compound 4 lay 1.3-fold (0.12 log units) below the measured number, within the range that was stated.
By their numbers in this assay, from the lowest: compounds 2 and 3 (each within the scatter of the next); then compounds 1 and 4 (each within the scatter of the next).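

At this aromatic carbon, nitro in place of butyl costs a large step in this assay (a 50-fold higher number from compound 3 to compound 4 (1.70 log units; beyond the scatter)), and nitro in place of ethyl costs one of the same printed size (a 50-fold higher number from compound 2 to compound 4 (1.70 log units; beyond the scatter)). Nitro in place of bromo makes no difference beyond the scatter (a 1.1-fold higher number from compound 1 to compound 4 (0.05 log units; within the scatter)). Among these four compounds, then, the two alkyl groups give the low numbers, while two quite different non-alkyl groups give numbers that cannot be told apart.

No evidence here explains this gap. As far as these compounds go, whether an amine or a carboxylic acid at this carbon would join the alkyl compounds or the bromo and nitro compounds stays open.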